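The compounds below may be only part of what the source reports. "The series", "measured", "known", "first", "only" and "open" are said of these compounds alone.

Series notes. In a functional assay on the whole organism with Mus musculus as the target (on this read-out lower numbers stand for an effect already at smaller amounts and higher numbers for an effect only at larger amounts of compound), compound 1 `CCCCOc1ccc2nncn2n1` reaches only a limit of the assay, > 100 mg/kg. Compound 2 `CCCCCOc1ccc2nncn2n1` gives 39.4 mg/kg in this assay. Compound 3 `CCCCCCCCCOc1ccc2nncn2n1` also stops at a limit of the assay, > 100 mg/kg. Compound 4 `CCCCCCCCCCOc1ccc2nncn2n1` is still to be measured in this assay.

The change methyl in place of hydrogen on a saturated chain carbon, four bonds along the chain from an oxygen on an aromatic ring produced the step of an at least 2.5-fold lower number from compound 1 to compound 2 (0.40 log units; beyond the scatter). Between the cores of compound 1 and compound 3 the difference is pentyl in place of hydrogen on a saturated chain carbon, four bonds along the chain from an oxygen on an aromatic ring, and the step was a step that the two limits leave unreadable from compound 1 to compound 3. From compound 2 to compound 3 the step was an at least 2.5-fold higher number from compound 2 to compound 3 (0.40 log units; beyond the scatter); two of the three values sit at the limit of > 100 mg/kg in this assay, at which 2 of the 3 values shown sit.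

For the measured compounds named here, the change methyl in place of hydrogen on a saturated chain carbon, nine bonds along the chain from an oxygen on an aromatic ring is the same kind of change as the one from compound 1 to compound 2, but its place is nine bonds along the chain from an oxygen on an aromatic ring instead of four bonds along the chain from an oxygen on an aromatic ring. The step from compound 3 to compound 4 is expected to be about a step that the limit leaves unreadable from compound 3 to compound 4 in this assay. The expectation rests on compound 3, whose value > 100 mg/kg is a limit of the assay. Compound 4 is estimated at 150 mg/kg in this assay, between 60 mg/kg and 400 mg/kg.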

Compound 4, dose for half-maximal effect: > 100 mg/kg
Compound 4 gave a limit, no number (the forecaster's own chance of this, stated with the estimate: 75%); the middle value is on the limit's open side.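

In this assay compound 4 stops at a limit of the assay, > 100 mg/kg. For the compounds shown here, the one new step that can be read is an at least 2.5-fold higher number from compound 2 to compound 4 (0.40 log units; beyond the scatter), while the same methyl change that gave an at least 2.5-fold lower number from compound 1 to compound 2 (0.40 log units; beyond the scatter) yields no readable step when carried to the core of compound 3. The steps from compound 3 to compound 4 and from compound 1 to compound 4 cannot be read, so the series does not show whether the methyl change has the same effect, a different effect or none on this longer chain, because the values at both ends of each step are limits: the limit of > 100 mg/kg in this assay, at which 3 of the 4 values shown sit.

Still open, from the compounds shown here alone, is how the read-out runs for a hexyl, heptyl or octyl chain on the oxygen of the shared core, and whether any of these gives a number rather than a limit. Also open, going by these compounds, is whether an amine or a carboxylic acid on the chain would change the read-out.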